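The source may report more compounds than this note shows. Statements on the series, on what has been measured and on what is new or still open speak of the compounds shown alone.

Working notes on the series.

Compound 1 `Cc1ccc(S/C(=C/c2sccc2C)C(=O)c2ccc(Br)cc2)cc1` is measured in a functional assay on DU-145 cells (Homo sapiens) for inhibition, read by trypan blue exclusion, with a stated time of 96 h (on this read-out higher numbers stand for weaker inhibition of growth and lower numbers for stronger inhibition of growth), and gives 50000 nM. Compound 2 `Cc1ccc(S/C(=C/c2sccc2C)C(=O)c2ccc(Cl)cc2)cc1` gives 50000 nM in this assay, so the step of no change at the digits printed from compound 1 to compound 2 (within the scatter) lies within the scatter, and compound 1 and compound 2 stand together at the highest number of the three measured. Going by the values given here, compound 3 `COc1ccc(S/C(=C/c2ccc(Cl)cc2Cl)C(=O)c2ccc(Br)cc2)cc1` gives 1000 nM in this assay, a number far lower than that of compound 1; compound 3 differs from compound 1 in two places, so no single step is drawn between them.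

Compound 4 `Cc1ccc(S/C(=C/c2ccc(N(C)C)cc2)C(=O)c2ccc(Br)cc2)cc1` is not yet measured. It differs from compound 1 as follows: 4-(dimethylamino)phenyl in place of 3-methylthiophen-2-yl on a double-bonded chain carbon bound to a double-bonded chain carbon. Among the compounds with values here, the only measured single step, no change at the digits printed from compound 1 to compound 2 (within the scatter), concerns a halogen swap on a different ring and says nothing about the exchange at the double-bonded chain carbon. Compound 3 shows that a compound with a six-membered carbon ring at that position can sit at 1000 nM, but its second change leaves the attribution open.

For compound 4 in this assay the value is therefore expected near 10000 nM, in the range 2000 nM to 50000 nM. The step of a 5.0-fold lower number from compound 1 to compound 4 (0.70 log units; beyond the scatter) is an estimate with wide uncertainty.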

Compound 4, concentration for 50% growth inhibition: > 100000 nM
Compound 4 ended at the assay's limit; the forecaster's own chance of this, stated with the estimate: 30%; middle value at least 10-fold (1.00 log units) away from the limit.
By their numbers in this assay, from the lowest: compound 3; then compounds 1 and 2 (each within the scatter of the next). At a limit, above all of these: compound 4.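

In this assay compound 4 gives > 100000 nM as a limit of the assay, not as a number. Going by these compounds alone, this is the first single change read at the double-bonded chain carbon, and the result, an at least 2.0-fold higher number from compound 1 to compound 4 (0.30 log units; that floor lies within the scatter) in this exchange, gives no sign that 4-(dimethylamino)phenyl in place of 3-methylthiophen-2-yl brings the number down, although the floor of the step does not separate the two compounds. The reading of compound 4 is a limit, so only that floor is known and the true size of the step stays undefined: the limit of > 100000 nM in this assay, at which 1 of the 4 values shown sits.

The compounds shown do not separate the exchange of the ring from the dimethylamino group itself, and a plain phenyl or a phenyl carrying a primary amine at this carbon would be needed to tell the two apart. Within the data shown here, compound 3 differs from compound 4 in more than one place, so no step between them can be read, and what the ring at this carbon contributes to the value of compound 3 stays open.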